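Methyl for Methoxy, Tried Once and Tried Again

The source may hold more compounds than are shown below. What is called first, only, known or untested is meant among the compounds shown, and "the series" means these compounds.

Measured so far:
compound 1, `COc1ccc(NC(=S)Nn2c(S)nnc2-c2ccncc2)cc1`: 1300 nM
compound 2, `Cc1ccc(NC(=S)Nn2c(S)nnc2-c2ccncc2)cc1`: 1230 nM
compound 3, `COc1ccc(Nc2nn3c(-c4ccncc4)nnc3s2)cc1`: 333 nM

These three compounds were tested in a functional assay on HepG2 cells (Homo sapiens) for cytotoxicity, read by sulforhodamine B assay, with a stated time of 24 h; a higher number here means a weaker inhibitor, a lower number a stronger inhibitor. Compound 1 and compound 2 share one core and differ by a single change, (methyl in place of methoxy on an aromatic carbon). That change made a step of a 1.1-fold lower number from compound 1 to compound 2 (0.02 log units; within the scatter), so the two compounds are, for practical purposes, indistinguishable in this assay.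

Compound 3 is built on a different core; how its core differs from that of compound 1 is not broken down here. In this assay compound 3 gives 333 nM, a lower number than compound 1 and compound 2, and both gaps lie beyond the scatter.

Compound 4, `Cc1ccc(Nc2nn3c(-c4ccncc4)nnc3s2)cc1`, has not yet been measured. It stands to compound 3 as compound 2 stands to compound 1: the change is methyl in place of methoxy on an aromatic carbon, at the same place in the same words. Because the earlier instance of this change gave a 1.1-fold lower number from compound 1 to compound 2 (0.02 log units; within the scatter), the step from compound 3 to compound 4 is expected to be small, about a 1.0-fold lower number from compound 3 to compound 4 (0.02 log units; within the scatter). Compound 4 is therefore estimated to give 320 nM in this assay, expected to fall between 150 nM and 680 nM.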

Compound 4, half-maximal inhibitory concentration: 312 nM
Compound 4: middle estimate off by 1.0-fold (0.01 log units), on the high side; the measured number falls inside the stated range.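

In this assay, replacing methoxy with methyl on the aromatic ring gave a 1.1-fold lower number from compound 3 to compound 4 (0.03 log units; within the scatter), so compound 3 and compound 4 cannot be told apart in this test. The same replacement had already made no measurable difference on the other core, and the two steps agree closely: the same change on two cores in this assay, a 1.1-fold lower number (0.02 log units; within the scatter) from compound 1 to compound 2 and a 1.1-fold lower number (0.03 log units; within the scatter) from compound 3 to compound 4, 1.0-fold (0.00 log units) apart, within the scatter of two such steps. This shows that, in these two pairs, a result seen on one core carried over to the other, but two cores are a small sample, so it does not show that the replacement would pass unnoticed on every core in this series, nor does it explain why the two groups give such similar numbers.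

The compounds shown hold methoxy or methyl at this place, para to a large group, so what an amine, a carboxylic acid or a longer chain would do there stays open. Whether a larger change at this place would also carry from one core to the other is equally unsettled.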